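This account rests on a few compounds, and the source may have more. Where it says the series, first, only, none or still open, it means among the compounds named here.

Three compounds share one core and differ only in their aryl groups. Compound 1 `CN(C(=O)NC(=O)c1cccc(C(F)(F)F)c1)c1nc(C(F)(F)F)c(C(=O)N/N=C/c2ccccc2C(F)(F)F)s1` gives 7.69 ug/mL in a functional assay on MCF7 cells (Homo sapiens) for inhibition, read by MTT assay, with a stated time of 72 h; a higher number here means a weaker inhibitor, a lower number a stronger inhibitor. Compound 2 `CN(C(=O)NC(=O)c1c(F)cccc1F)c1nc(C(F)(F)F)c(C(=O)N/N=C/c2cccc(C(F)(F)F)c2)s1` gives 21.8 ug/mL in this assay, and compound 3 `CN(C(=O)NC(=O)c1ccc(F)c(F)c1)c1nc(C(F)(F)F)c(C(=O)N/N=C/c2cccc(C(F)(F)F)c2)s1` gives 4.15 ug/mL in this assay. Of the three numbers, compound 3 shows the smallest, though its difference from compound 1 lies within the scatter, while the step of a 5.3-fold lower number from compound 2 to compound 3 (0.72 log units; beyond the scatter) is beyond it. Compound 4 `CN(C(=O)NC(=O)c1cccc(C(F)(F)F)c1)c1nc(C(F)(F)F)c(C(=O)N/N=C/c2cccc(C(F)(F)F)c2)s1` is not yet measured. It differs from compound 3 in one place: 3-(trifluoromethyl)phenyl in place of 3,4-difluorophenyl on a carbonyl carbon. For the measured compounds named here, the only measured step at this position, a 5.3-fold lower number from compound 2 to compound 3 (0.72 log units; beyond the scatter), shows that exchanging the aryl group on the carbonyl carbon can shift the number by a modest amount. Compound 1 already carries the 3-(trifluoromethyl)phenyl group on its carbonyl carbon and gives 7.69 ug/mL, within the scatter of compound 3. Compound 4 is therefore expected to give a number close to that of compound 3, with the step of a 1.4-fold higher number from compound 3 to compound 4 (0.16 log units; within the scatter) estimated to stay small. The estimate for compound 4 is 6 ug/mL, with a range from 2.5 ug/mL to 15 ug/mL.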

Compound 4, half-maximal inhibitory concentration: 3.7 ug/mL
For compound 4 the middle estimate is 1.6-fold (0.21 log units) above the measured one; low and high end bracket the measured number.
By their numbers in this assay, from the lowest: compounds 4, 3 and 1 (each within the scatter of the next, the first and the last beyond it); then compound 2.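

In this assay, for the compounds shown here, the aryl group on the carbonyl carbon can change in kind without a clear change in the number: 3-(trifluoromethyl)phenyl in place of 3,4-difluorophenyl gives a 1.1-fold lower number from compound 3 to compound 4 (0.05 log units; within the scatter) and so reads the same as the difluoro group, while a 5.9-fold lower number from compound 2 to compound 4 (0.77 log units; beyond the scatter) shows that 2,6-difluorophenyl is again the one group set apart at this position. The aryl group on the carbon with a double bond to nitrogen now has a readable step too, with 3-(trifluoromethyl)phenyl in place of 2-(trifluoromethyl)phenyl giving a 2.1-fold lower number from compound 1 to compound 4 (0.32 log units; beyond the scatter) as a modest change. Nothing at hand gives a reason for any of these steps.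

On these data alone, whether the carbonyl position accepts a plain phenyl or a group carrying an amine or a carboxylic acid remains open. As far as these compounds go, the step at the second position rests on a single pair, so whether it holds with 3,4-difluorophenyl on the carbonyl is also open.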